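The source may report more compounds than this note shows. Statements on the series, on what has been measured and on what is new or still open speak of the compounds shown alone.

Measured so far in an ADME assay for permeability, using PAMPA, with a stated time of 30 min, at pH 7.4; on this read-out lower numbers stand for lower permeability and higher numbers for higher permeability:
compound 1 `COc1ccc(F)cc1CNCCCNc1ccnc2cc(Cc3ccc(F)cc3Cl)ccc12` gives 23 10^-6 cm/s
compound 2 `COc1ccc(F)cc1CNCCCNc1ccnc2cc(Cc3cc(C)cc(C)c3)ccc12` gives 23 10^-6 cm/s

Compound 2 stands level with compound 1 at the digits shown; the step of no change at the digits printed from compound 1 to compound 2 (within the scatter) lies within the scatter, and the change there was an aryl swap on a saturated chain carbon. Compound 3 `COc1ccc(F)cc1CNCCCNc1ccnc2cc(Oc3ccccc3OC)ccc12` is the next compound in the series. Its difference from compound 2 is 2-methoxyphenoxy in place of 3,5-dimethylbenzyl on an aromatic carbon. Going by the values given here, this change is of a different kind from the one step so far measured: the linking atom to the shared core changes along with the ring, and acceptors enter where none left. Among the compounds with values here, the one step that bears on it, the step from compound 1 to compound 2 in this assay, showed no change beyond the scatter, but it did not alter the link or the acceptor count, so it gives only weak guidance. A small step downward, or none beyond the scatter, is therefore expected for compound 3, that is a 1.5-fold lower number from compound 2 to compound 3 (0.19 log units; within the scatter). In this assay compound 3 is estimated at 15 10^-6 cm/s, with a range from 6 10^-6 cm/s to 32 10^-6 cm/s.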

Compound 3, apparent permeability: 317 10^-6 cm/s
Beside the measured number, compound 3's estimate is 21-fold (1.32 log units) below it, and the stated range ends below it.
By their numbers in this assay, from the lowest: compounds 1 and 2 (each within the scatter of the next); then compound 3.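

In this assay, 2-methoxyphenoxy on this aromatic carbon gives a 14-fold higher number from compound 2 to compound 3 (1.14 log units; beyond the scatter) in place of 3,5-dimethylbenzyl and a 14-fold higher number from compound 1 to compound 3 (1.14 log units; beyond the scatter) in place of 2-chloro-4-fluorobenzyl. The position therefore does not stay flat on this read-out: the exchange of one benzyl group for the other gave only no change at the digits printed from compound 1 to compound 2 (within the scatter), whereas the exchange of a benzyl group for a phenoxy group moves the number well beyond the scatter. The change is a joint one, with the atom linking the ring to the shared core altered while hydrogen-bond acceptors enter where the leaving groups had none, and no evidence at hand says which part of it carries the step.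

On these data alone, it remains open whether the step follows the linking oxygen or the methoxy group, a question on which an unsubstituted phenoxy group and a 2-methoxybenzyl group on the same aromatic carbon would bear directly. Also open, as far as these compounds go, is whether another link, such as an amine nitrogen in an anilino group, would give a step of similar size in this assay.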